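The source may report more compounds than this note shows. Statements on the series, on what has been measured and on what is new or still open speak of the compounds shown alone.

Compound 1 `O=C(Nc1cc(F)cc(F)c1)c1ccc2cccnc2c1O`: 510 nM
Compound 2 `O=C(Nc1cc(C(F)(F)F)cc(C(F)(F)F)c1)c1ccc(Cl)cc1O`: 200 nM
Compound 3 `N#Cc1ccc(NC(=O)c2cc(Cc3ccccc3)ccc2O)cc1`: 1740 nM

These numbers come from a functional assay on HL-60 cells (Homo sapiens) for cytotoxicity, read by luminescence and CellTiter-Glo, with a stated time of 3 days; a higher number here means a weaker inhibitor, a lower number a stronger inhibitor. Among the three, compound 3 gives the highest number; compound 1 lies nearest and compound 2 furthest, and both gaps go beyond the usual scatter, so compound 3 is the weakest inhibitor of the three. Compound 4 `N#Cc1ccc(NC(=O)c2cc(-c3ccncc3)ccc2O)cc1` has not yet been measured. It differs from compound 3 in one place: pyridin-4-yl in place of benzyl on an aromatic carbon. For the measured compounds named here, no measured pair shows this change, so its size cannot be read off from the data. A small step is expected in this assay, probably within the scatter, with a lean toward a weaker inhibitor. The expected step is a 1.3-fold higher number from compound 3 to compound 4 (0.10 log units; within the scatter). For compound 4 the estimate is 2200 nM, within a range from 700 nM to 7000 nM.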

Compound 4, half-maximal inhibitory concentration: 5410 nM
For compound 4 the middle estimate is 2.5-fold (0.39 log units) below the measured one; the measured number falls inside the stated range.
By their numbers in this assay, from the lowest: compound 2; then compound 1; then compound 3; then compound 4.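

In this assay the position para to the hydroxy group proves sensitive to this swap, with a 3.1-fold higher number from compound 3 to compound 4 (0.49 log units; beyond the scatter) when pyridin-4-yl replaces benzyl. The entering group has one heavy atom fewer and carries a hydrogen-bond acceptor, while the leaving group has none, so the change is not a single clean difference. Nothing measured here explains the shift. As far as these compounds go, it remains open whether the ring nitrogen or the benzyl's extra carbon matters more. A plain phenyl group on the same carbon would separate the two.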